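Swapping in 3-iodophenyl on a compound at the assay limit

The source may hold more compounds than are shown below. What is called first, only, known or untested is meant among the compounds shown, and "the series" means these compounds.

Compound 1 `COc1ccccc1Oc1c(N)nc(-c2cccc(I)c2)nc1Cl` at 2200 nM
Compound 2 `COc1ccccc1Oc1c(N)nc(-c2ccc(F)cc2)nc1OCCO` at 15900 nM
Compound 3 `COc1ccccc1Oc1c(N)nc(-c2ccc(Cl)cc2)nc1OCCO` at > 80000 nM which is a limit and not a number

All three results come from a functional assay on A-375 cells (Homo sapiens) for cytotoxicity, read by CCK-8 assay, with a stated time of 24 h (a higher number here means a weaker inhibitor, a lower number a stronger inhibitor), and give the half-maximal inhibitory concentration. Compound 3 stands at the limit of > 80000 nM in this assay, at which 1 of the 3 values shown sits, and so has no measured number.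

Compound 4 `COc1ccccc1Oc1c(N)nc(-c2cccc(I)c2)nc1OCCO` has not yet been measured. It differs from compound 3 by 3-iodophenyl in place of 4-chlorophenyl on an aromatic carbon with 3-iodophenyl in place of 4-chlorophenyl on an aromatic carbon between two ring nitrogen atoms.

Among the compounds with values here, one measured step bears directly on this change. The step of an at least 5.0-fold higher number from compound 2 to compound 3 (0.70 log units; beyond the scatter) lies beyond the scatter, so a single change on this aromatic group can shift the result in this assay visibly. Compound 1 also carries 3-iodophenyl and gives 2200 nM in this assay, while the 2-hydroxyethoxy group of compound 4 is retained in compound 2, which gives 15900 nM as a measured number. On that basis a lower number, meaning a stronger inhibitor, is expected. The expected change is an at least 6.6-fold lower number from compound 3 to compound 4 (0.82 log units; beyond the scatter) and it should lie beyond the scatter. For compound 4 the estimated value is 12000 nM with an expected range from 3000 nM to 50000 nM in this assay.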

Compound 4, half-maximal inhibitory concentration: 1230 nM
For compound 4 the middle estimate is 9.8-fold (0.99 log units) above the measured one, and the stated range ends above it.
By their numbers in this assay, from the lowest: compounds 4 and 1 (each within the scatter of the next); then compound 2. At a limit, above all of these: compound 3.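

With the 2-hydroxyethoxy group held constant in this assay, placing 3-iodophenyl on the aromatic carbon between two ring nitrogen atoms gives a 13-fold lower number from compound 2 to compound 4 (1.11 log units; beyond the scatter), and the same group gives an at least 65-fold lower number from compound 3 to compound 4 (1.81 log units; beyond the scatter), so this one aryl group separates compound 4 from both compounds with a para-halogenated ring. The other single change tells a different story: 2-hydroxyethoxy in place of chloro gives a 1.8-fold lower number from compound 1 to compound 4 (0.25 log units; within the scatter), which lies within the scatter, so with 3-iodophenyl present, the two groups at that site give no visible difference in this read-out. Compound 3 stands at a limit and not a number, so the step from it fixes only a bound and not a true size: the limit of > 80000 nM in this assay, at which 1 of the 4 values shown sits.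

The compounds shown cannot separate the iodine atom from its ring position, and 4-iodophenyl or 3-chlorophenyl on the same core would be needed to tell these two apart. Going by these compounds, it also remains open whether the flat result at the other site extends beyond chloro and 2-hydroxyethoxy, for instance to an amine or a longer chain ending in a carboxylic acid.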